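Dimethylcarbamoyl for hydroxymethyl on compound 1

The source may report more compounds than this note shows. Statements on the series, on what has been measured and on what is new or still open speak of the compounds shown alone.

In a physicochemical assay for lipophilicity, using the shake flask method, in phosphate buffer, measured as octanol-water partition, with a stated time of 30 min, at pH 7.4 (on this read-out higher numbers stand for higher lipophilicity and lower numbers for lower lipophilicity), compound 1 `Cc1nc(CO)ccc1-c1cnc(NCc2c(F)ccc3c2CCO3)c2cn[nH]c(=O)c12` gives 2.4. Compound 3 `CN(c1ccn(C)n1)c1cnc(NCc2c(F)ccc3c2CCO3)c2cn[nH]c(=O)c12` gives the same figure, 2.4, and compound 2 `CN(C)C(=O)c1cc(-c2cnc(NCc3c(F)ccc4c3CCO4)c3cn[nH]c(=O)c23)n(C)n1` gives 2.1, within the scatter of the other two. Compound 4 `Cc1nc(C(=O)N(C)C)ccc1-c1cnc(NCc2c(F)ccc3c2CCO3)c2cn[nH]c(=O)c12` has not yet been measured. It differs from compound 1 in one place, with dimethylcarbamoyl in place of hydroxymethyl on an aromatic carbon, next to the ring nitrogen: dimethylcarbamoyl in place of hydroxymethyl on an aromatic carbon.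

Among the measured compounds shown here, no measured step isolates this exchange. The closest is a number 0.30 log units lower from compound 1 to compound 2 (within the scatter), which replaces the whole 6-(hydroxymethyl)-2-methylpyridin-3-yl group with 3-(dimethylcarbamoyl)-1-methyl-1H-pyrazol-5-yl. The other two measured steps, no change at the digits printed from compound 1 to compound 3 (within the scatter) and a number 0.30 log units higher from compound 2 to compound 3 (within the scatter), also exchange a whole group, and all three stay within the scatter. A smaller exchange is therefore not expected to move this assay beyond the scatter. The estimated step is a number 0.10 log units lower from compound 1 to compound 4 (within the scatter), and no firm direction can be claimed for it. Compound 4 is expected at 2.3. Its estimated range runs from 1.9 to 2.7.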

Compound 4, distribution coefficient: 2.1
For compound 4 the middle estimate is 0.20 log units above the measured one, within the range that was stated.
By their numbers in this assay, from the lowest: compounds 2, 4, 1 and 3 (each within the scatter of the next).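

In this assay the exchange at this position, on an aromatic carbon next to the ring nitrogen, can now be read on its own, with the rest of compound 1 unchanged: a number 0.30 log units lower from compound 1 to compound 4 (within the scatter). Hydroxymethyl has 1 hydrogen-bond donor and 2 heavy atoms, dimethylcarbamoyl has 0 hydrogen-bond donors and 5 heavy atoms, and this difference in the counts still leaves the read-out within the scatter. Nothing in the data gives a measured reason for this result.

The compounds shown leave open whether a carboxylic acid, an amine or a longer chain at this same place would also stay within the scatter. They also leave open whether the same exchange would read alike without the methyl group on that ring.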